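The source may hold more compounds than are shown below. What is called first, only, known or untested is meant among the compounds shown, and "the series" means these compounds.

Going by the values given here, in a functional assay on HCT-116 cells (Homo sapiens) for inhibition, read by MTT assay, with a stated time of 72 h (on this read-out lower numbers stand for stronger inhibition of growth and higher numbers for weaker inhibition of growth), compound 1 `CCOC(=O)/C=C/c1ccncc1-c1ccc2ccccc2c1` gives 910 nM, the only number available in this small set. Compound 2 `O=C(O)CCNC(=O)/C=C/c1ccncc1-c1ccc2ccccc2c1` shares the core of compound 1, but the entry of compound 2 reads "not determined" (no result reported), so compound 2 has no place on the scale and offers no number to start from.

The next structure, compound 3 `O=C(/C=C/c1ccncc1-c1ccc2ccccc2c1)N1CCOCC1`, carries morpholin-4-yl in place of (2-carboxyethyl)amino on a carbonyl carbon. Among the compounds with values here, with no measured step to guide the size of this change, the expectation rests on compound 1 at 910 nM alone. In this assay the expected result is a value of similar size, perhaps slightly weaker, with no large step in either direction. Compound 3 is estimated at 1500 nM, with an expected range of 450 nM to 5000 nM.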

Compound 3, concentration for 50% growth inhibition: 6040 nM
The estimate for compound 3 lay 4.0-fold (0.60 log units) below the measured number, and the stated range ends below it.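

Going by these compounds alone, this gives the first measured comparison at this position: in this assay, putting morpholin-4-yl in place of ethoxy on a carbonyl carbon gives a 6.6-fold higher number from compound 1 to compound 3 (0.82 log units; beyond the scatter) and so means weaker inhibition of growth. Within the data shown here, the group on this carbonyl carbon can therefore change the result by more than the usual scatter, whereas compound 2 has no value and no step involving it can be read. Nothing measured here explains why this change weakens the effect.

A single step cannot show whether the ring itself or simply the loss of ethoxy matters. Going by these compounds, it also remains open whether an open-chain amine such as dimethylamino, or a carboxylic acid, on the same carbonyl carbon would give a number closer to that of compound 1 or compound 3.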